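The source may report more compounds than this note shows. Statements on the series, on what has been measured and on what is new or still open speak of the compounds shown alone.

Of the compounds shown here, three sharing one core have been tested in a functional assay on 4T1 cells (Homo sapiens) for cytotoxicity, read by MTT assay, with a stated time of 48 h; on this read-out lower numbers stand for stronger inhibition and higher numbers for weaker inhibition. Compound 1 `CC(C)n1c(/C=C2/C(=O)Nc3ccc(F)cc32)nc2ccccc21` gives 25800 nM, and compound 3 `CCn1c(/C=C2/C(=O)Nc3ccc(Br)cc32)nc2ccccc21` gives 40700 nM. These two values lie within the usual scatter of each other. Compound 2 `Cn1c(/C=C2/C(=O)Nc3ccc([N+](=O)[O-])cc32)nc2ccccc21` gives > 50000 nM, which is a limit of the assay and not a number. It is the only one of the three without a measured number.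

Compound 4 `Cn1c(/C=C2/C(=O)Nc3ccc(F)cc32)nc2ccccc21` differs from compound 2 in one place, with fluoro in place of nitro on an aromatic carbon. Among the measured compounds shown here, no measured pair shows this change alone, so any forecast is loose. The closest guide is compound 1, which also carries fluoro and reaches a number, 25800 nM, in this assay. A modest shift towards stronger inhibition is therefore expected, though it may prove small. The estimated size of the change is an at least 1.5-fold lower number from compound 2 to compound 4 (0.19 log units; that floor lies within the scatter). For compound 4 the expected value is 32000 nM, with an estimated range from 14000 nM to 50000 nM.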

Compound 4, half-maximal inhibitory concentration: 29600 nM
Compound 4: middle estimate off by 1.1-fold (0.03 log units), on the high side; measured number inside the range.
By their numbers in this assay, from the lowest: compounds 1, 4 and 3 (each within the scatter of the next). At a limit, above all of these: compound 2.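

With fluoro in place of nitro on this aromatic carbon, a number replaces a limit, and the change reads as an at least 1.6-fold lower number from compound 2 to compound 4 (0.22 log units; that floor lies within the scatter) for the pair with methyl on the aromatic nitrogen. That size is only a floor, because compound 2 sits at a limit of the assay and not at a number: the limit of > 50000 nM in this assay, at which 1 of the 4 values shown sits. Methyl in place of isopropyl on the aromatic nitrogen, with fluoro kept, gives a 1.1-fold higher number from compound 1 to compound 4 (0.06 log units; within the scatter) and so shows that fluoro gives a similar number with either of these two groups.

From the compounds shown here alone, how far apart fluoro and nitro truly lie remains open, since the nitro side has no number. Also open, going by these compounds, is whether an amine, a methoxy group or a carboxylic acid on this carbon would move the number beyond the scatter.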